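The compounds below may be only part of what the source reports. "The series", "measured", "known", "first", "only" and "open" are said of these compounds alone.

Three ureas on the shared core have been measured so far. Compound 1 `O=C(Nc1ccc(Br)cc1)N[C@H]1CC[C@H](Oc2ccc(F)cc2)CC1` carries a 4-bromophenyl on the urea nitrogen; in a functional assay on CRL2813 cells (Homo sapiens) for cytotoxicity, read by sulforhodamine B assay, with a stated time of 5 days (a lower number here means a stronger inhibitor, a higher number a weaker inhibitor), compound 1 reaches only the limit > 20000 nM. Compound 2 `O=C(Nc1cccc(Cl)c1)N[C@H]1CC[C@H](Oc2ccc(F)cc2)CC1` gives 5900 nM in this assay. Compound 3 `Cc1ccccc1NC(=O)N[C@H]1CC[C@H](Oc2ccc(F)cc2)CC1` likewise stops at the limit > 20000 nM in this assay. It thus stands with compound 1 rather than with compound 2, as an at least 3.3-fold higher number from compound 2 to compound 3 (0.53 log units; beyond the scatter) and an at least 3.3-fold lower number from compound 1 to compound 2 (0.53 log units; beyond the scatter) show. Compound 4 `O=C(Nc1ccccc1Br)N[C@H]1CC[C@H](Oc2ccc(F)cc2)CC1` differs from compound 3 in one place (bromo in place of methyl on an aromatic carbon). Among the compounds with values here, no measured step covers this change; the two compounds at the limit of > 20000 nM in this assay, at which 2 of the 3 values shown sit, both lack a 3-chlorophenyl. The chemist therefore expects no step beyond the scatter, a number no higher from compound 3 to compound 4 (the limit leaves the size open). For compound 4 the expected value is 20000 nM, between 8000 nM and 50000 nM.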

Compound 4, half-maximal inhibitory concentration: 7700 nM
Compound 4: the middle estimate sits 2.6-fold (0.41 log units) above what was measured, and the stated range ends above it.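

Bromo and methyl are not interchangeable at this place on the aromatic ring: this assay shows an at least 2.5-fold lower number from compound 3 to compound 4 (0.41 log units; beyond the scatter). Within the data shown here, a 3-chlorophenyl is also not the only group that leaves the limit, as the change to 2-bromophenyl gives a 1.3-fold higher number from compound 2 to compound 4 (0.12 log units; within the scatter). Where the bromo sits matters as well, with an at least 2.5-fold lower number from compound 1 to compound 4 (0.41 log units; beyond the scatter).

As far as these compounds go, how far compound 1 and compound 3 lie past their shared value stays open, as it is a limit and not a number: the limit of > 20000 nM in this assay, at which 2 of the 4 values shown sit. Also open is how a 2-chlorophenyl or a 3-bromophenyl would fare on the shared core.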